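Series notes: amide to urea on the shared core

A few compounds are considered here, and "the series" means these few. Any claim that something is new, unique, unknown or untested is made for them only; others in the source may bear on it.

Measured in a functional assay on NCI-H460 cells (Homo sapiens) for inhibition, read by sulforhodamine B assay, with a stated time of 48 h; a higher number here means a weaker inhibitor of growth, a lower number a stronger inhibitor of growth:
compound 1 `O=C(Nc1cccc(-n2cc(-c3ccncc3)c(-c3ccc(Cl)c(O)c3)n2)c1)Nc1cccc(C(F)(F)F)c1`: 29000 nM
compound 2 `COc1cc(-c2nn(-c3cccc(NC(=O)Nc4cc(C(F)(F)F)cc(C(F)(F)F)c4)c3)cc2-c2ccncc2)ccc1Cl`: 1870 nM
compound 3 `COc1cc(-c2nn(-c3cccc(NC(=O)c4cccc(C(F)(F)F)c4)c3)cc2-c2ccncc2)ccc1Cl`: 9270 nM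

Compound 3 stands second highest of the three numbers. Compound 1 gives a higher number than compound 3, and compound 2 a lower one; both gaps lie beyond the scatter. Among the measured compounds shown here, compound 2 and compound 3 differ in more than one place, so no single-change step among the measured compounds is available.

Compound 4 `COc1cc(-c2nn(-c3cccc(NC(=O)Nc4ccc(Cl)c(Cl)c4)c3)cc2-c2ccncc2)ccc1Cl` is the next member. It differs from compound 3 in one place: (3,4-dichlorophenyl)amino in place of 3-(trifluoromethyl)phenyl on a carbonyl carbon. The urea is the feature shared with compound 2, which holds the lowest number, and with compound 1, which holds the highest; the measured set does not separate this change from the others present in those two compounds.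

The step from compound 3 to compound 4 is expected to be modest and toward a lower number, a 2.6-fold lower number from compound 3 to compound 4 (0.42 log units; beyond the scatter). Compound 4 is thus expected to give about 3500 nM in this assay, within a range of 1000 nM to 12000 nM.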

Compound 4, concentration for total growth inhibition: > 50000 nM
Compound 4: no number, only a limit (the forecaster's own chance of this, stated with the estimate: 5%); middle value at least 14-fold (1.15 log units) from the limit.
By their numbers in this assay, from the lowest: compound 2; then compound 3; then compound 1. At a limit, above all of these: compound 4.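

In this assay, (3,4-dichlorophenyl)amino in place of 3-(trifluoromethyl)phenyl on a carbonyl carbon gives an at least 5.3-fold higher number from compound 3 to compound 4 (0.73 log units; beyond the scatter), so moving to a urea at this position does not by itself bring a lower number. Compound 4 has only a limit and no exact number: the limit of > 50000 nM in this assay, at which 1 of the 4 values shown sits.

Compound 4 differs from compound 2 only in the aryl group on the urea, and compound 2 gives 1870 nM, so what the urea carries counts at this position as well as the urea itself.

The step from the amide to the urea also changes the ring substituents, and the compounds shown do not separate these two parts. On these data alone, how this position responds to a urea ring carrying a carboxylic acid or a dimethylamino group in place of the chlorines remains open.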